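Trifluoromethyl for Chloro: Expected Agonist Response

The source may report more compounds than this note shows. Statements on the series, on what has been measured and on what is new or still open speak of the compounds shown alone.

Compound 2 `CSc1ccc(Cl)cc1NCC1=NCCN1` gives 82% in a functional assay for agonist activity at Alpha-1A adrenergic receptor (Homo sapiens) (on this read-out lower numbers stand for smaller maximal responses and higher numbers for larger maximal responses), the smaller of the two numbers measured, though compound 1 `CSc1ccc(F)cc1NCC1=NCCN1` with 90% lies within the scatter of it, and the step of a number 8 percentage points lower from compound 1 to compound 2 (within the scatter) is the only one known. Compound 3 `CSc1ccc(C(F)(F)F)cc1NCC1=NCCN1` differs from compound 2 by trifluoromethyl in place of chloro on an aromatic carbon. For the measured compounds named here, that single step, within the scatter, is the only guide, and it points to little movement. Compound 3 is therefore estimated at 82% in this assay, between 68% and 96%. The step of no change at the digits printed from compound 2 to compound 3 (within the scatter) that this estimate means is expected to stay within the scatter.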

Compound 3, largest response reached (reported as maximum), in percent of the reference or control that the assay uses: 111%
Beside the measured number, compound 3's estimate is 29 percentage points below it; measured number outside the range, above it.
By their numbers in this assay, from the lowest: compounds 2 and 1 (each within the scatter of the next); then compound 3.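

In this assay this position proved sensitive to the group placed on it: fluoro and chloro could not be told apart, but trifluoromethyl brings a number 29 percentage points higher from compound 2 to compound 3 (beyond the scatter) and a number 21 percentage points higher from compound 1 to compound 3 (beyond the scatter) and so sets compound 3 apart from both halogen compounds. The response therefore does not stay flat across every replacement at this aromatic carbon. Nothing available accounts for this rise. On these data alone, whether the higher response is particular to trifluoromethyl remains open, as does what an amine, a methoxy group or a nitrile would give at this position.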